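The source may hold more compounds than are shown below. What is called first, only, known or untested is meant among the compounds shown, and "the series" means these compounds.

Measured compounds:
- compound 1, `CNc1nc(NCCC2CCN(C)C2)nc2ccc(Cl)cc12`: 11700 nM
- compound 2, `CN1CCN(c2ncc3cc(Cl)ccc3n2)CC1`: 7.41 nM

In an assay on HEK293 cells for displacement of a labelled ligand from 5-hydroxytryptamine receptor 3A (Homo sapiens), read by scintillation counting, with a stated time of 24 h, in the presence of a further agent that is not named here (on this read-out higher numbers stand for weaker inhibition and lower numbers for stronger inhibition), compound 2 gives 7.41 nM, the lowest of the two numbers recorded. Among the measured compounds shown here, compound 1 gives 11700 nM; its number is far beyond the scatter from that of compound 2, but the two structures differ in more than one place, so no single step connects them and their two values show only that compound 1 is the weaker of the pair.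

The step under consideration leads from compound 2 to compound 3, `CN1CCN(c2nc(NCC3CCCCC3)c3cc(Cl)ccc3n2)CC1`. The change is (cyclohexylmethyl)amino in place of hydrogen on an aromatic carbon. The core and its 4-methylpiperazin-1-yl group are retained, and the only addition is the (cyclohexylmethyl)amino group on the ring carbon described.

For the measured compounds named here, no measured step shows what such an addition does on this core. A change of this size is expected to move the number beyond the scatter, and the expectation is that it moves towards weaker inhibition, so that the step from compound 2 to compound 3 is estimated as a 5.4-fold higher number from compound 2 to compound 3 (0.73 log units; beyond the scatter). For compound 3 in this assay the estimated value is 40 nM, with a range from 8 nM to 300 nM.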

Compound 3, inhibition constant: 16600 nM
The estimate for compound 3 lay 420-fold (2.62 log units) below the measured number; the measured number lies above the stated range.
By their numbers in this assay, from the lowest: compound 2; then compounds 1 and 3 (each within the scatter of the next).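

Compound 2 gave no earlier view of this position, and the step now supplies one. On the aromatic carbon next to the ring nitrogen and meta to the 4-methylpiperazin-1-yl group, (cyclohexylmethyl)amino in place of hydrogen gives a 2200-fold higher number from compound 2 to compound 3 (3.35 log units; beyond the scatter) in this assay, a large step towards weaker inhibition. With the core and the 4-methylpiperazin-1-yl group retained, this one addition separates compound 2 at 7.41 nM from compound 3 at 16600 nM, so on this core the position does not take this group without a heavy loss, and nothing available accounts for the size of that loss.

The compounds shown leave open whether the loss follows any group on this carbon or this particular one, a question that a plain amino group or a cyclohexyl ring attached directly to the carbon would help to settle on the same core. From the compounds shown here alone, it also remains open whether the step would be of similar size if a morpholine ring stood in place of the 4-methylpiperazin-1-yl group.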